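A few compounds are considered here, and "the series" means these few. Any claim that something is new, unique, unknown or untested is made for them only; others in the source may bear on it.

Measured so far:
compound 1 `CCOC(=O)C1=Cc2ccccc2OC1(OCc1cn(CC(=O)Nc2cccc(F)c2)nn1)C(F)(F)F` — > 150000 nM
compound 2 `CCOC(=O)C1=Cc2ccccc2OC1(OCc1cc(-c2cccc(C(F)(F)F)c2)no1)C(F)(F)F` — 57300 nM

In a functional assay on DU-145 cells (Homo sapiens) for inhibition, read by MTT assay, with a stated time of 24 h (on this read-out higher numbers stand for weaker inhibition and lower numbers for stronger inhibition), compound 1 gives only a limit, > 150000 nM, so it stands at the edge of what this assay can report: the limit of > 150000 nM in this assay, at which 1 of the 2 values shown sits. Compound 2, the other measured member, gives 57300 nM in this assay. Compound 3 `CCOC(=O)C1=Cc2ccccc2OC1(OCc1cn(CC(=O)Nc2ccc(I)cc2Cl)nn1)C(F)(F)F` is not yet measured; it differs from compound 1 in one place: 2-chloro-4-iodophenyl in place of 3-fluorophenyl on an amide-type nitrogen. For the measured compounds named here, no measured pair shows this change, so its size is not known from these two compounds; with compound 1 at the limit, no step beyond the scatter is expected in either direction, and a limit reading is again likely. The estimate for compound 3 is 120000 nM with a range of 40000 nM to 300000 nM. The step this implies, an at least 1.2-fold lower number from compound 1 to compound 3 (0.09 log units; that floor lies within the scatter), is expected to be small.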

Compound 3, half-maximal inhibitory concentration: 24400 nM
For compound 3 the middle estimate is 4.9-fold (0.69 log units) above the measured one; the measured number lies below the stated range.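

In this assay the group on the amide-type nitrogen can shift the read-out: 2-chloro-4-iodophenyl in place of 3-fluorophenyl gives an at least 6.1-fold lower number from compound 1 to compound 3 (0.78 log units; beyond the scatter) and brings this series a number rather than a limit. Compound 3 gives 24400 nM in this triazole-free wording of the series' amide arm. Compound 1 stays a limit, so the full size of the step cannot be read: the limit of > 150000 nM in this assay, at which 1 of the 3 values shown sits.

The compounds shown do not separate the chlorine from the iodine in this change. On these data alone, how an amine or a carboxylic acid on this phenyl ring would read remains open.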